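Estimating Compound 4 from Three Measured Analogues

A few compounds are considered here, and "the series" means these few. Any claim that something is new, unique, unknown or untested is made for them only; others in the source may bear on it.

Measured in a functional assay on A549 cells (Homo sapiens) for antiproliferative activity, read by MTT assay, with a stated time of 48 h (on this read-out lower numbers stand for stronger inhibition and higher numbers for weaker inhibition), so far:
Compound 1 `C#Cc1cccc(Nc2ncnc3sc(NC(=O)/C=C/c4ccccc4)cc23)c1` — 10100 nM
Compound 2 `O=C(/C=C/c1ccccc1)Nc1cc2ncnc(Nc3cc(Cl)cc(Cl)c3)c2s1` — 12500 nM
Compound 3 `N#Cc1cccc(Nc2ncnc3cc(NC(=O)/C=C/c4ccccc4)sc23)c1` — 17200 nM

Compound 1 shows the lowest of the three numbers, yet its gaps to compound 2 and compound 3 both lie within the scatter, so the three cannot be ranked. Compound 4 `O=C(/C=C/c1ccccc1)Nc1cc2c(Nc3cccc(Cl)c3F)ncnc2s1` differs from compound 1 by 3-chloro-2-fluorophenyl in place of 3-ethynylphenyl on a nitrogen on an aromatic ring. For the measured compounds named here, the only measured step touching the same place is a 1.4-fold higher number from compound 2 to compound 3 (0.14 log units; within the scatter), which stayed within the scatter when one ring replaced another on that nitrogen. On that basis the step of a 1.1-fold higher number from compound 1 to compound 4 (0.04 log units; within the scatter) is expected to be small, with no direction beyond the scatter. Compound 4 is therefore estimated at 11000 nM, within a range from 5000 nM to 25000 nM.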

Compound 4, half-maximal inhibitory concentration: 26200 nM
Beside the measured number, compound 4's estimate is 2.4-fold (0.38 log units) below it; measured number outside the range, above it.
By their numbers in this assay, from the lowest: compounds 1, 2, 3 and 4 (each within the scatter of the next, the first and the last beyond it).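

In this assay, a change on this nitrogen now gives a step beyond the scatter: a 2.6-fold higher number from compound 1 to compound 4 (0.41 log units; beyond the scatter). The group on this nitrogen can therefore shift the number, which the step between compound 2 and compound 3 did not show. Nothing measured here explains the step.

The compounds shown leave open whether the chlorine, the fluorine or the loss of the ethynyl group matters most. As far as these compounds go, how a plain phenyl, or a phenyl carrying an amine or a carboxylic acid, would read on this nitrogen also remains open.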